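The source may hold more compounds than are shown below. What is called first, only, known or untested is meant among the compounds shown, and "the series" means these compounds.

In a functional assay on MCF7 cells (Homo sapiens) for inhibition, read by fluorescence, with a stated time of 72 h (a lower number here means a stronger inhibitor of growth, a higher number a weaker inhibitor of growth), compound 3 (`CCCCn1cnc2c(Nc3cc(OC)cc(OC)c3)nc(N[C@H]3CC[C@H](N)CC3)nc21`) gives 4500 nM, in the same range as compound 1 (`CC(C)=CCn1cnc2c(Nc3cccc(Cl)c3)nc(N[C@H]3CC[C@H](N)CC3)nc21`) at 4200 nM. Compound 2 (`CC(C)CCn1cnc2c(Nc3cccc(Cl)c3)nc(N[C@H]3CC[C@H](N)CC3)nc21`) gives 2100 nM, a lower number than compound 3 by more than the scatter. Compound 4 (`CCCCn1cnc2c(Nc3cccc(Cl)c3)nc(N[C@H]3CC[C@H](N)CC3)nc21`) carries 3-chlorophenyl in place of 3,5-dimethoxyphenyl on a nitrogen on an aromatic ring. For the measured compounds named here, no measured step covers this exchange. Going by the values given here, the only measured step, a 2.0-fold lower number from compound 1 to compound 2 (0.30 log units; within the scatter), is a chain change between compounds that both carry 3-chlorophenyl. Compound 4 is therefore expected near those two values in this assay, with no clear shift from compound 3 beyond the scatter. The estimated step is a 1.5-fold lower number from compound 3 to compound 4 (0.18 log units; within the scatter). For compound 4 the estimated value is 3000 nM, with an expected range of 1500 nM to 6000 nM.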

Compound 4, concentration for 50% growth inhibition: 2000 nM
Estimate against measurement, compound 4: 1.5-fold (0.18 log units) above; low and high end bracket the measured number.
By their numbers in this assay, from the lowest: compounds 4, 2, 1 and 3 (each within the scatter of the next, the first and the last beyond it).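

For the compounds shown here, on the nitrogen on an aromatic ring, 3-chlorophenyl in place of 3,5-dimethoxyphenyl gives a 2.3-fold lower number from compound 3 to compound 4 (0.35 log units; beyond the scatter) in this assay and is the first reading of this exchange, a modest one beyond the scatter. With 3-chlorophenyl held, hydrogen in place of methyl on the chain gives a 1.1-fold lower number from compound 2 to compound 4 (0.02 log units; within the scatter) and leaves the number unchanged within the scatter, while propyl in place of 2-methylprop-1-en-1-yl gives a 2.1-fold lower number from compound 1 to compound 4 (0.32 log units; beyond the scatter) as a modest step. No supporting data bear on the reason for either the aryl or the chain steps. From the compounds shown here alone, whether phenyl or 3-methoxyphenyl on that nitrogen would read with compound 3 or with compound 4 remains open.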